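Ester Variation at the Phenol of a Kinase-Targeting Scaffold

The source may hold more compounds than are shown below. What is called first, only, known or untested is meant among the compounds shown, and "the series" means these compounds.

Measured compounds:
compound 1, `CC(=O)Oc1ccc(Cn2ccnc2)c2cccnc12`, 28500 nM
compound 2, `CC(=O)Oc1ccc(Cn2cnc(F)c2)c2cccnc12`, 2900 nM

For the measured compounds named here, in a functional assay on MV4-11 cells (Homo sapiens) for antiproliferative activity, read by luminescence, with a stated time of 72 h (a higher number here means a weaker inhibitor, a lower number a stronger inhibitor), compound 1 gives 28500 nM, the higher of the two numbers measured; compound 2 gives 2900 nM, and the single measured step is a 9.8-fold lower number from compound 1 to compound 2 (0.99 log units; beyond the scatter). Compound 3, `O=C(Oc1ccc(Cn2ccnc2)c2cccnc12)c1ccccc1`, differs from compound 1 by phenyl in place of methyl on a carbonyl carbon. Going by the values given here, the measured step concerns the imidazole ring, not the ester, so it does not bear on this change; no measured step does. Compound 3 is therefore expected to lie close to compound 1, with a 1.4-fold lower number from compound 1 to compound 3 (0.15 log units; within the scatter) as the expected step. The estimated value for compound 3 is 20000 nM, within 4000 nM to 100000 nM.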

Compound 3, half-maximal inhibitory concentration: 9000 nM
Compound 3: the middle estimate sits 2.2-fold (0.35 log units) above what was measured; measured number inside the range.
By their numbers in this assay, from the lowest: compound 2; then compound 3; then compound 1.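

For the compounds shown here, the ester position is not silent: in this assay, phenyl in place of methyl on the carbonyl carbon gives a 3.2-fold lower number from compound 1 to compound 3 (0.50 log units; beyond the scatter) and so provides the first reading at this site, since the earlier step concerned only the imidazole ring. Acetyl to benzoyl thus moves the number on its own, though only modestly. Nothing available here accounts for this shift.

From the compounds shown here alone, it remains open whether a longer chain or an amine in place of the methyl would move the number in the same direction. Going by these compounds, whether the benzoyl change and fluoro in place of hydrogen would add together also remains open.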